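Cytotoxicity working notes on two measured compounds and one pending

A few compounds are considered here, and "the series" means these few. Any claim that something is new, unique, unknown or untested is made for them only; others in the source may bear on it.

Measured so far:
compound 1 `O=C(CN1CCN(c2ccc(Cl)cc2)CC1)N1CCN(c2nnc(-c3ccccc3)c(-c3ccccc3)n2)CC1`: 113000 nM
compound 2 `COc1ccc(-c2nnc(N3CCN(C(=O)CN4CCN(c5ccccc5OC)CC4)CC3)nc2-c2ccc(OC)cc2)cc1`: > 821000 nM

In an ADME assay on NIH3T3 cells (Mus musculus) for cytotoxicity, read by MTT assay, with a stated time of 24 h (on this read-out higher numbers stand for weaker inhibition and lower numbers for stronger inhibition), compound 1 gives 113000 nM. For compound 2 this assay reports only a limit, > 821000 nM. Compound 2 thus stands at the edge of the measured range, as noted: the limit of > 821000 nM in this assay, at which 1 of the 2 values shown sits. Compound 3 `COc1ccc(-c2nnc(N3CCN(C(=O)CN4CCN(c5ccc([N+](=O)[O-])cc5)CC4)CC3)nc2-c2ccc(OC)cc2)cc1` is still to be measured in this assay. It differs from compound 2 by 4-nitrophenyl in place of 2-methoxyphenyl on an amine nitrogen in a ring. Among the compounds with values here, no step between measured compounds is available; compound 1 and compound 2 differ in several places, so their two values show only that both are weak inhibitors in this assay. With compound 2 at a limit, the step of an at least 1.3-fold lower number from compound 2 to compound 3 (0.13 log units; that floor lies within the scatter) is expected to be none beyond the scatter, with no clear direction. Compound 3 is therefore expected to give about 600000 nM, with a range from 200000 nM to 1500000 nM, and a fair chance that this assay again reports only a limit.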

Compound 3, half-maximal inhibitory concentration: > 801000 nM
Compound 3: a limit, no number (the forecaster's own chance of this, stated with the estimate: 50%); at least 1.3-fold (0.12 log units) between middle value and limit.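

In this assay compound 3 gives only a limit, > 801000 nM. Compound 2 also gives only a limit, > 821000 nM, so no step can be read between compound 2 and compound 3. As far as these compounds go, whether 4-nitrophenyl in place of 2-methoxyphenyl on an amine nitrogen in a ring shifts the value in this assay stays open.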